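A few compounds are considered here, and "the series" means these few. Any claim that something is new, unique, unknown or untested is made for them only; others in the source may bear on it.

Compound 1, `Cc1cc(=O)oc2cc(OCc3cn(-c4ccc(Cl)cc4)nn3)ccc12`, gives > 100 ug/mL in an ADME assay on Huh-7 cells (Homo sapiens) for cytotoxicity, read by MTT assay, with a stated time of 72 h; on this read-out higher numbers stand for lower toxicity in this test and lower numbers for higher toxicity in this test.
Compound 2, `Cc1cc(=O)oc2cc(OCc3cn(-c4ccc(OC(F)(F)F)cc4)nn3)ccc12`, gives > 100 ug/mL in this assay.
Compound 3, `CC(=O)Nc1ccc(-n2cc(COc3ccc4c(C)cc(=O)oc4c3)nn2)cc1`, gives > 100 ug/mL in this assay.

Each of these three values is a limit of the assay rather than a measured number. Compound 1 therefore stands at the limit, and no number places it against the others. The step that the two limits leave unreadable from compound 1 to compound 2 cannot be sized, nor can a step that the two limits leave unreadable from compound 1 to compound 3 or a step that the two limits leave unreadable from compound 2 to compound 3, since each pair rests on two limits. What the three compounds share is the limit of > 100 ug/mL in this assay, at which 3 of the 3 values shown sit, and that is all the data say about how the group on the triazole nitrogen touches toxicity on these cells.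

Compound 4, `Cc1cc(C)cc(-n2cc(COc3ccc4c(C)cc(=O)oc4c3)nn2)c1`, is not yet measured. It differs from compound 1 by 3,5-dimethylphenyl in place of 4-chlorophenyl on an aromatic nitrogen. Every measured step that changes this same position leaves the value at the limit, so no readable step is available to set an expectation of a shift in either direction. Compound 4 is therefore expected to sit at or beyond the limit as well, with the step that the limit leaves unreadable from compound 1 to compound 4 expected to be unreadable in the same way. The estimate for compound 4 in this assay is 150 ug/mL, with a range from 60 ug/mL to 400 ug/mL.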

Compound 4, half-maximal cytotoxic concentration: > 100 ug/mL
Compound 4 was reported as a limit; the forecaster's own chance of this, stated with the estimate: 85%; the middle value lies beyond the limit too.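

No new step can be read between compound 1 and compound 4, since both values in this assay are limits and not measured numbers: the limit of > 100 ug/mL in this assay, at which 4 of the 4 values shown sit.

The compounds shown leave open whether any of the four truly differs from another in toxicity on these cells, and whether any group on that aromatic nitrogen would give a measurable number.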